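The compounds below may be only part of what the source reports. "The series", "measured", "known", "first", "only" and "open" are said of these compounds alone.

Working notes on the series.

Compound 1 `Clc1ccc(C2NN=C3CCCCC32)cc1` serves as the reference point. In a physicochemical assay for lipophilicity, measured as octanol-water partition (on this read-out lower numbers stand for lower lipophilicity and higher numbers for higher lipophilicity), compound 1 gives 4.4. Compound 2 `Fc1ccc(C2NN=C3CCCCC32)cc1` differs from it by one change, namely (fluoro in place of chloro on an aromatic carbon). In this assay compound 2 gives 4. The step between the two is a number 0.40 log units lower from compound 1 to compound 2 (beyond the scatter).

Compound 3 `O=S(=O)(c1ccccc1)N1N=C2CCCCC2C1c1ccc(Cl)cc1` is built on a second core; the difference between the two cores is not broken down here. In this assay compound 3 gives 5.4, the highest of the three numbers measured, and of the other two compound 1 is the nearer.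

Compound 4 `O=S(=O)(c1ccccc1)N1N=C2CCCCC2C1c1ccc(F)cc1` has not yet been measured in this assay. Relative to compound 3 it carries fluoro in place of chloro on an aromatic carbon. The place of the change is described as para to a large group, whereas in the earlier pair it is para to a group of 9 heavy atoms, so the two changes are the same kind of change, not the same.

Among the measured compounds shown here, the step expected in this assay is a number 0.40 log units lower from compound 3 to compound 4 (beyond the scatter), resting on the measured step of a number 0.40 log units lower from compound 1 to compound 2 (beyond the scatter), since no other pair carries this change. Compound 4 is accordingly estimated at 5 in this assay, with the expected range running from 4.7 to 5.3. The measured number for compound 4 will show whether the second core carries the change in the same way.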

Compound 4, partition coefficient: 5
Estimate against measurement, compound 4: no gap at the digits printed; the measured number falls inside the stated range.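

The chloro to fluoro change gives a number 0.40 log units lower from compound 3 to compound 4 (beyond the scatter) in this assay, and on the core of compound 1 it gives a number 0.40 log units lower from compound 1 to compound 2 (beyond the scatter), so the printed size of the step is the same on both cores. Among the compounds shown here, this supports carrying this one change between these two cores for this read-out, with neither pair going against it, but it rests on only two pairs, each with the change in the same printed place, 4-chlorophenyl to 4-fluorophenyl, and it does not establish a rule for other changes, other cores or other read-outs. Nothing given here accounts for the match between the two steps, which may or may not reflect a shared origin, and the agreement stands as an observation only.

The compounds shown leave open whether a larger replacement for the chloro, such as methoxy or trifluoromethyl, would also give matching steps on the two cores. For the compounds shown here, they also leave open whether an amine or a carboxylic acid in that place would carry across in the same way, since every substituent compared here is a single halogen atom and the two pairs cover only that narrow swap.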